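Adding a Second Methoxy to Compound 1

This account rests on a few compounds, and the source may have more. Where it says the series, first, only, none or still open, it means among the compounds named here.

Measured compounds:
- Compound 1, `COc1ccccc1-c1cn(-c2ccc(O)c(C(=O)Nc3cccc(C(F)(F)F)c3)c2)nn1`: 65%
- Compound 2, `COC(=O)c1cc(-n2cc(-c3ccccc3OC)nn2)ccc1O`: 6%
- Compound 3, `COc1ccccc1-c1cn(-c2ccc(O)c(C(=O)O)c2)nn1`: 9%

In a functional assay on CCRF-CEM cells (Homo sapiens) for inhibition, read by MTT assay, with a stated time of 2 days, tested at 10 uM (a lower number here means less inhibition, a higher number more inhibition at the concentration tested (going by the name of the read-out)), compound 1 gives the highest of the three numbers; both others lie well below it, as the steps of a number 59 percentage points lower from compound 1 to compound 2 (beyond the scatter) and a number 56 percentage points lower from compound 1 to compound 3 (beyond the scatter) show. Those two steps both replace the (3-(trifluoromethyl)phenyl)amino group on the carbonyl carbon, and the step of a number 3 percentage points higher from compound 2 to compound 3 (within the scatter) changes only the oxygen next to the carbonyl group. Compound 4, `COc1ccc(OC)c(-c2cn(-c3ccc(O)c(C(=O)Nc4cccc(C(F)(F)F)c4)c3)nn2)c1`, keeps that amide untouched and instead carries methoxy in place of hydrogen on an aromatic carbon, turning 2-methoxyphenyl into 2,5-dimethoxyphenyl. Among the measured compounds shown here, no measured step touches this part of the structure, so nothing shows how the number responds to it. The expected step is a number 5 percentage points lower from compound 1 to compound 4 (within the scatter), none beyond the scatter. Compound 4 is estimated at 60%, between 35% and 80%.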

Compound 4, a percentage reported as inhibition, at one concentration (the size of the read-out at that concentration, not a potency): 15%
Compound 4: middle estimate off by 45 percentage points, on the high side; measured number outside the range, below it.
By their numbers in this assay, from the lowest: compounds 2, 3 and 4 (each within the scatter of the next); then compound 1.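

The earlier steps shown here all changed the amide end of compound 1, and this one shows that the other end matters as well. In this assay a single added methoxy gives a number 50 percentage points lower from compound 1 to compound 4 (beyond the scatter) on an aromatic carbon meta to a large group and para to a methoxy group, so 2-methoxyphenyl to 2,5-dimethoxyphenyl is far from a neutral change, even with the amide intact. No measurement here explains the drop. The compounds shown leave open whether it is specific to methoxy, since a hydroxy or a fluorine on this same carbon could respond differently.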